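A few compounds are considered here, and "the series" means these few. Any claim that something is new, unique, unknown or untested is made for them only; others in the source may bear on it.

Compound 1 `CCC(=O)NCCCO[C@H]1[C@H](C)[C@@H](O[C@@H]2O[C@H](C)C[C@H](N(C)C)[C@H]2O)[C@](C)(O)C[C@@H](C)CN(C)[C@H](C)[C@@H](O)[C@](C)(O)[C@@H](CC)OC(=O)[C@@H]1C` is the smaller of two macrolides carrying a propanoylamino chain, and in a physicochemical assay for lipophilicity, read by HPLC, measured as chromatographic lipophilicity, at pH 7.4 (a higher number here means a more lipophilic compound, a lower number a more polar compound), compound 1 gives 1.6. Compound 2 `CC[C@H]1OC(=O)[C@H](C)[C@@H](OCCCNC(=O)C2CCC2)[C@H](C)[C@@H](O[C@@H]2O[C@H](C)C[C@H](N(C)C)[C@H]2O)[C@](C)(O)C[C@@H](C)CN(C)[C@H](C)[C@@H](O)[C@]1(C)O` differs from it by cyclobutyl in place of ethyl on a carbonyl carbon, and in this assay compound 2 gives 1.78. That change produced a number 0.18 log units higher from compound 1 to compound 2 (within the scatter). Compound 3 `CCC(=O)NCCCO[C@@H]1[C@@H](C)N(C)C[C@H](C)C[C@@](C)(O)[C@H](O[C@@H]2O[C@H](C)C[C@H](N(C)C)[C@H]2O)[C@@H](C)[C@H](O[C@H]2C[C@@](C)(OC)[C@@H](O)[C@H](C)O2)[C@@H](C)C(=O)O[C@H](CC)[C@@]1(C)O` carries a further sugar; how its core differs from that of compound 1 is not broken down here, and in this assay compound 3 gives 2.74, the highest of the three. Compound 4 `CC[C@H]1OC(=O)[C@H](C)[C@@H](O[C@H]2C[C@@](C)(OC)[C@@H](O)[C@H](C)O2)[C@H](C)[C@@H](O[C@@H]2O[C@H](C)C[C@H](N(C)C)[C@H]2O)[C@](C)(O)C[C@@H](C)CN(C)[C@H](C)[C@@H](OCCCNC(=O)C2CCC2)[C@]1(C)O` makes the same change on the core of compound 3: cyclobutyl in place of ethyl on a carbonyl carbon. Because the earlier step of a number 0.18 log units higher from compound 1 to compound 2 (within the scatter) was small, compound 4 is expected to move by a number 0.16 log units higher from compound 3 to compound 4 (within the scatter) beside it. Compound 4 is therefore estimated at 2.9, between 2.6 and 3.2.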

Compound 4, distribution coefficient: 3.5
Estimate against measurement, compound 4: 0.60 log units below, outside the stated range (above it).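

On the core of compound 3, cyclobutyl in place of ethyl on a carbonyl carbon gave a number 0.76 log units higher from compound 3 to compound 4 (beyond the scatter) in this assay against a number 0.18 log units higher from compound 1 to compound 2 (within the scatter) on the core of compound 1 and so the size of the step on one core did not carry over to the other. This rests on only these two pairs and shows nothing about how the change would behave on any further core. Nothing shown here accounts for the difference between the two steps. Still open, going by these compounds, is whether a cyclopropyl group or a longer chain such as butyl in place of ethyl on that carbonyl carbon would also give steps that differ between the two cores.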